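This account rests on a few compounds, and the source may have more. Where it says the series, first, only, none or still open, it means among the compounds named here.

In an assay on membranes from HEK293 cells for displacement of a labelled ligand from adenosine receptor A2b (Homo sapiens), read by scintillation counting, with a stated time of 30 min, tested at 1 uM (a higher number here means more inhibition at the concentration tested (going by the name of the read-out), a lower number less inhibition), compound 3 `CC1=C(C(=O)OC(C)(C)C)C(c2ccsc2)NC(=O)N1` gives 47%, the highest of the three numbers shown, although compound 1 `COC(=O)C1=C(C)NC(=O)NC1c1ccoc1` with 42% and compound 2 `CC1=C(C(=O)OC(C)(C)C)C(c2cccs2)NC(=O)N1` with 38% both lie within the scatter of it. Within the data shown here, the single step measured in one place, a number 9 percentage points higher from compound 2 to compound 3 (within the scatter), concerns the ring on the saturated ring carbon and leaves the group on the oxygen next to the carbonyl group untouched. Compound 4 `CC1=C(C(=O)OCc2ccccc2)C(c2ccsc2)NC(=O)N1` differs from compound 3 exactly there: benzyl in place of tert-butyl on an oxygen next to a carbonyl group. Among the measured compounds shown here, no measured pair changes that group alone; compound 1 carries a different group on that oxygen but also a different ring, so its value says nothing about this change by itself. A step of no clear direction is therefore expected, a number 2 percentage points lower from compound 3 to compound 4 (within the scatter). Compound 4 is estimated to give 45%, between 20% and 70%.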

Compound 4, a percentage reported as inhibition, at one concentration (the size of the read-out at that concentration, not a potency): 44%
Estimate against measurement, compound 4: 1 percentage points above; low and high end bracket the measured number.
By their numbers in this assay, from the lowest: compounds 2, 1, 4 and 3 (each within the scatter of the next).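

With the thiophen-3-yl ring held fixed, the group on the oxygen next to a carbonyl group now has a step of its own: in this assay, benzyl in place of tert-butyl gives a number 3 percentage points lower from compound 3 to compound 4 (within the scatter). Here, going from 4 to 7 heavy atoms and adding a six-membered aromatic ring does not move the number beyond the usual scatter. As far as these compounds go, whether a longer chain or a carboxylic acid in this place would do so stays open. Nothing measured speaks to what lies behind these numbers.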